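The source may report more compounds than this note shows. Statements on the series, on what has been measured and on what is new or still open speak of the compounds shown alone.

Working notes on the series.

Within the data shown here, compound 2, `CCCSc1nc2nc(C)cc(N3CC[C@@H](C)[C@@H](N(C)c4ncnc5[nH]ccc45)C3)n2n1`, gives 67100 nM in a toxicity assay on GES1 cells (Homo sapiens) for inhibition, read by MTT assay, with a stated time of 72 h (a higher number here means a weaker inhibitor, a lower number a stronger inhibitor), the higher of the two numbers measured so far; its nearest neighbour is compound 1, `Cc1cc(N2CC[C@@H](C)[C@@H](N(C)c3ncnc4[nH]ccc34)C2)n2ncnc2n1`, which in this assay gives 57900 nM. Among the measured compounds shown here, the one measured step, a 1.2-fold higher number from compound 1 to compound 2 (0.06 log units; within the scatter), adds propylsulfanyl to an aromatic carbon and stays within the scatter.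

Compound 3, `Cc1cc(N2CC[C@@H](C)[C@@H](N(C)c3ncnc4[nH]ccc34)C2)n2nc(SCc3cc(Cl)ccc3Cl)nc2n1`, differs from compound 2 by 2,5-dichlorophenyl in place of ethyl on a saturated chain carbon bound to a sulfur. For the measured compounds named here, no measured step carries an aryl group into this part of the molecule, so the only comparison available is the sulfanyl step itself, which moved nothing beyond the scatter. The change in compound 3 is larger than that, but there is no measured footing for a direction, so any expected movement is small and uncertain.

For compound 3 the estimate in this assay is 40000 nM, with a range of 12000 nM to 110000 nM; this expected step, a 1.7-fold lower number from compound 2 to compound 3 (0.22 log units; within the scatter), is at the edge of the scatter.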

Compound 3, half-maximal inhibitory concentration: 87500 nM
Compound 3: middle estimate off by 2.2-fold (0.34 log units), on the low side; the range from low to high includes it.
By their numbers in this assay, from the lowest: compounds 1, 2 and 3 (each within the scatter of the next).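

In this assay, the aromatic carbon that took propylsulfanyl also accepts a group carrying an aromatic ring and two chlorines, with a 1.5-fold higher number from compound 1 to compound 3 (0.18 log units; within the scatter) for the whole (2,5-dichlorobenzyl)sulfanyl group. On the saturated chain carbon bound to a sulfur, 2,5-dichlorophenyl in place of ethyl gives a 1.3-fold higher number from compound 2 to compound 3 (0.12 log units; within the scatter), so this larger change, like the propylsulfanyl step, stays inside the scatter and all three compounds read alike at this position. Nothing measured here bears on why this change leaves the reading in place.

Still open, as far as these compounds go, is whether a plain benzyl would read the same as 2,5-dichlorobenzyl on the sulfur. Also open, from the compounds shown here alone, is whether an amine or a carboxylic acid at the end of this chain would move the number beyond the scatter.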